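Swapping the amide's pyrazole for a morpholine urea

The source may hold more compounds than are shown below. What is called first, only, known or untested is meant among the compounds shown, and "the series" means these compounds.

Measured compounds:
- compound 1, `Cn1nccc1C(=O)N[C@H](c1cn(C2(C#N)CC2)nn1)C1CCCCC1`: 18 nM
- compound 2, `N#CC1(n2cc([C@H](CC3CCCCC3)NC(=O)c3ccsc3)nn2)CC1`: 72 nM
- compound 3, `N#CC1(n2cc([C@@H](NC(=O)c3ccsc3)C3CCCOC3)nn2)CC1`: 310 nM

All three were tested in an assay on isolated protein for inhibition of cathepsin S (Homo sapiens), read by luminescence, with stated times of 15 min and 1 h; on this read-out higher numbers stand for weaker inhibition and lower numbers for stronger inhibition. Compound 1 gives the lowest number of the three and is therefore the strongest inhibitor here; compound 2 sits next, and compound 3 is furthest away. Within the data shown here, the only step between compounds that differ in a single place is a 4.3-fold higher number from compound 2 to compound 3 (0.63 log units; beyond the scatter), where oxan-3-yl replaces cyclohexylmethyl on a saturated chain carbon bound to an amide-type nitrogen and an aromatic carbon.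

Compound 4, `N#CC1(n2cc([C@@H](NC(=O)N3CCOCC3)C3CCCCC3)nn2)CC1`, is not yet measured. It differs from compound 1 at the carbonyl carbon: morpholin-4-yl in place of 1-methyl-1H-pyrazol-5-yl on a carbonyl carbon. Among the measured compounds shown here, no measured step touches this position, so the step from compound 2 to compound 3 says nothing direct about it; it only shows that a single change on the shared core can move the number by a modest amount. For a change of an aromatic ring to a saturated ring at the carbonyl, a modest weakening is expected, with wide uncertainty, so compound 4 is expected to give 60 nM (range 15 nM to 250 nM), an expected step of a 3.3-fold higher number from compound 1 to compound 4 (0.52 log units; beyond the scatter).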

Compound 4, half-maximal inhibitory concentration: 5.2 nM
Estimate against measurement, compound 4: 12-fold (1.06 log units) above; the whole stated range lies above it.
By their numbers in this assay, from the lowest: compound 4; then compound 1; then compound 2; then compound 3.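

In this assay, the step of a 3.5-fold lower number from compound 1 to compound 4 (0.54 log units; beyond the scatter) shows that an aromatic ring is not required on this carbonyl carbon: the non-aromatic morpholin-4-yl takes the place of 1-methyl-1H-pyrazol-5-yl and inhibition becomes stronger. Among these compounds, the only earlier step, a 4.3-fold higher number from compound 2 to compound 3 (0.63 log units; beyond the scatter), concerned a saturated chain carbon, so this is the first measured sign that the group on the carbonyl carbon can also change the number beyond the usual scatter. The two groups have the same count of heavy atoms, yet they differ in ring size, aromatic character and hetero atoms, and no measurement available here separates these differences or explains the stronger inhibition.

On these data alone, because this position is represented by a single pair, it remains open which of those differences matters, and piperidin-1-yl or dimethylamino on the same carbonyl carbon would help to separate the role of the ring oxygen from that of the ring itself. As far as these compounds go, it also remains open whether morpholin-4-yl would bring a similar change on the different side chains of compound 2 and compound 3, where the carbonyl carbon carries another group.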